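Shifting a chlorine across two matched pairs

A few compounds are considered here, and "the series" means these few. Any claim that something is new, unique, unknown or untested is made for them only; others in the source may bear on it.

Compound 1 `COc1ccc(C2N=C(SCc3cccc(Cl)c3)NC(C)=C2C(=O)Nc2ccc(F)cc2)cc1OC` gives 20.1% in a functional assay on the whole organism (artery, strain albino) with Rattus norvegicus as the target, with a stated time of 360 min, at a dose of 10 mg/kg by the oral route; a lower number here means less inhibition, a higher number more inhibition at the dose given (going by the name of the read-out). Compound 2 `COc1ccc(C2N=C(SCc3ccc(Cl)cc3)NC(C)=C2C(=O)Nc2ccc(F)cc2)cc1OC` gives 37.1% in this assay. Compound 3 `COc1ccc(C2N=C(SCc3cccc(Cl)c3)NC(C)=C2C(=O)Nc2ccc(Br)cc2)cc1` gives 39.7% in this assay.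

Compound 2 differs from compound 1 only by 4-chlorophenyl in place of 3-chlorophenyl on a saturated chain carbon bound to a sulfur, and this assay moved a number 17 percentage points higher from compound 1 to compound 2 (beyond the scatter). The difference between the core of compound 1 and the core of compound 3 is not broken down here; compound 3 and compound 2 give values within the scatter of each other, while compound 1 lies beyond the scatter below both.

Compound 4 `COc1ccc(C2N=C(SCc3ccc(Cl)cc3)NC(C)=C2C(=O)Nc2ccc(Br)cc2)cc1` is not yet measured. It differs from compound 3 by 4-chlorophenyl in place of 3-chlorophenyl on a saturated chain carbon bound to a sulfur, the same change at the same place as from compound 1 to compound 2. The step from compound 3 to compound 4 is expected to be a number 11.3 percentage points higher from compound 3 to compound 4 (beyond the scatter), somewhat smaller than the earlier one because compound 3 already stands at 39.7%. Compound 4 is therefore estimated at 51%, with a range from 33% to 68%.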

Compound 4, a percentage reported as inhibition, in the whole organism at one dose (the size of the read-out at that dose, not a potency): 39.2%
Estimate against measurement, compound 4: 11.8 percentage points above; the range from low to high includes it.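

In this assay, 4-chlorophenyl in place of 3-chlorophenyl on a saturated chain carbon bound to a sulfur gave a number 0.5 percentage points lower from compound 3 to compound 4 (within the scatter) on the core of compound 3. Set beside the earlier step, the same change did not carry over from one core to the other: the same change on two cores in this assay, a number 17 percentage points higher (beyond the scatter) from compound 1 to compound 2 and a number 0.5 percentage points lower (within the scatter) from compound 3 to compound 4, 17.5 percentage points apart, beyond the scatter of two such steps. The rise on the core of compound 1 therefore cannot be assumed on other cores in this series, but two matched pairs do not show which difference between the cores matters.

On these data alone, it remains open how the change would read on further cores. Also open, as far as these compounds go, is what an amine or a carboxylic acid in place of the chlorine, or a longer chain on the sulfur, would give.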